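Fluoro in place of methyl on compound 2

A few compounds are considered here, and "the series" means these few. Any claim that something is new, unique, unknown or untested is made for them only; others in the source may bear on it.

In a functional assay on A549 cells (Homo sapiens) for antiproliferative activity, read by MTT assay, with a stated time of 48 h (on this read-out lower numbers stand for stronger inhibition and higher numbers for weaker inhibition), compound 1 `Cc1ccc(C(=O)/C=C/c2cccc(Br)c2Oc2c([N+](=O)[O-])cc(C(F)(F)F)cc2[N+](=O)[O-])cc1` gives 6.85 ug/mL, compound 2 `Cc1ccc(C(=O)/C=C/c2cccc(Cl)c2Oc2c([N+](=O)[O-])cc(C(F)(F)F)cc2[N+](=O)[O-])cc1` gives 0.95 ug/mL, and compound 3 `COc1ccc(C(=O)/C=C/c2cc(Br)cc(Br)c2Oc2c([N+](=O)[O-])cc(C(F)(F)F)cc2[N+](=O)[O-])cc1` gives 13.2 ug/mL. Compound 2 has the lowest number of the three, and its gaps to both others lie beyond the scatter.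

Compound 4 `O=C(/C=C/c1cccc(Cl)c1Oc1c([N+](=O)[O-])cc(C(F)(F)F)cc1[N+](=O)[O-])c1ccc(F)cc1` departs from compound 2 in one place: fluoro in place of methyl on an aromatic carbon. This is fluoro in place of methyl on an aromatic carbon, para to a large group. Within the data shown here, only one measured step between compounds differing in one place is available: a 7.2-fold lower number from compound 1 to compound 2 (0.86 log units; beyond the scatter). That modest step, chloro in place of bromo on an aromatic carbon, lies at a different place and involves different groups. It shows that a single swap in this set can move the number in this assay beyond the scatter, but it does not give a direction for the new change. Among the measured compounds shown here, no measured pair compares methyl with fluoro. Compound 2, at 0.95 ug/mL, is already the lowest of the measured compounds, so a small rise is expected rather than a further fall. The expected change is a 1.6-fold higher number from compound 2 to compound 4 (0.20 log units; within the scatter), which would probably stay within the scatter. For compound 4 the estimated value is 1.5 ug/mL, with an expected range from 0.5 ug/mL to 6 ug/mL.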

Compound 4, half-maximal inhibitory concentration: 23.8 ug/mL
Estimate against measurement, compound 4: 16-fold (1.20 log units) below, and the stated range ends below it.
By their numbers in this assay, from the lowest: compound 2; then compounds 1, 3 and 4 (each within the scatter of the next, the first and the last beyond it).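

The change from 4-methylphenyl to 4-fluorophenyl gives a 25-fold higher number from compound 2 to compound 4 (1.40 log units; beyond the scatter) in this assay, so a single swap on an aromatic carbon para to a large group, at the far end of the molecule from the halogen, is enough to move the number well beyond the scatter. Among these compounds, until now the only single change on record was at the halogen, a 7.2-fold lower number from compound 1 to compound 2 (0.86 log units; beyond the scatter), and there are now two separate places where a single change away from compound 2 leaves a higher number, with compound 2 as the lowest of the four and the methyl and the chloro both present in it. No measurement shown here accounts for the size of this step.

The compounds shown leave open whether the rise follows the loss of the methyl or the arrival of the fluoro, a question that a plain phenyl, an ethyl group or an amine at this place would help to settle. Going by these compounds, it also remains open whether the same swap would read alike on compound 1, which carries bromo where compound 2 carries chloro.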